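The source may hold more compounds than are shown below. What is called first, only, known or untested is meant among the compounds shown, and "the series" means these compounds.

Measured so far in a functional assay on A549 cells (Homo sapiens) for inhibition, read by MTT assay, with a stated time of 24 h; on this read-out lower numbers stand for stronger inhibition and higher numbers for weaker inhibition:

- compound 1 `CCOC(=O)C1=Cc2ccccc2OC1(OCc1cc(-c2ccc(Br)cc2)no1)C(F)(F)F` — compound 1 gives the assay limit > 150000 nM.
- compound 2 `O=C(O)C1=Cc2ccccc2OC1(OCc1cc(-c2ccc([N+](=O)[O-])cc2)no1)C(F)(F)F` — compound 2 gives the assay limit > 150000 nM.
- compound 3 `CCOC(=O)C1=Cc2ccccc2OC1(OCc1cn(-c2ccccc2)nn1)C(F)(F)F` — compound 3 gives the assay limit > 150000 nM.

Among the measured compounds shown here, every value so far is a limit rather than a number, as the summary the limit of > 150000 nM in this assay, at which 3 of the 3 values shown sit, makes plain. For the measured compounds named here, compound 3 therefore stands nowhere on a scale: it sits at the limit, together with the two other measured compounds, and no step between any two measured compounds can be read off.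

Compound 4 `CCOC(=O)C1=Cc2ccccc2OC1(OCc1cn(CC(=O)Nc2ccc(I)cc2Cl)nn1)C(F)(F)F` has not been measured in this assay. It differs from compound 3 in one place: ((2-chloro-4-iodophenyl)carbamoyl)methyl in place of phenyl on an aromatic nitrogen. Going by the values given here, the data give no measured step of this or any other kind, so no size or direction can be drawn from them. The expectation for compound 4 is a step from compound 3 of a number no higher from compound 3 to compound 4 (the limit leaves the size open), none beyond the scatter. Compound 4 is estimated at 150000 nM, within 40000 nM to 400000 nM, with a further limit read-out the most likely outcome.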

Compound 4, half-maximal inhibitory concentration: 22300 nM
Beside the measured number, compound 4's estimate is 6.7-fold (0.83 log units) above it, outside the stated range (below it).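

In this assay, the group on the aromatic nitrogen of the five-membered ring is the first place in the series shown where a change registers: ((2-chloro-4-iodophenyl)carbamoyl)methyl in place of phenyl gives an at least 6.7-fold lower number from compound 3 to compound 4 (0.82 log units; beyond the scatter). On these data alone, the size of this step remains open at its upper end, and the change is a single composite one in which the carbonyl, the amide hydrogen, the chlorine and the iodine all enter together. Compound 4 alone gives a number rather than a limit, and steps among the other compounds cannot be read: the limit of > 150000 nM in this assay, at which 3 of the 4 values shown sit.

Which part of the entering group carries the step remains open, for example whether the same chain ending in an unsubstituted phenyl ring would hold it. Also open, as far as these compounds go, is whether a carboxylic acid in place of the ethyl ester would keep the activity of compound 4.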